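A few compounds are considered here, and "the series" means these few. Any claim that something is new, unique, unknown or untested is made for them only; others in the source may bear on it.

In an assay on cells for displacement of a labelled ligand from corticotropin-releasing factor receptor 1 (Homo sapiens), with a stated time of 100 min (a lower number here means a stronger inhibitor, a higher number a weaker inhibitor), compound 3 `CCCN(Cc1c(C(F)(F)F)nc2n(-c3c(C)cc(C)cc3C)c(Cl)cn12)CC1CCC1` gives 5.3 nM, the lowest of the three numbers shown, although its step to compound 1 stays within the scatter. Compound 1 `CCN(Cc1c(C(F)(F)F)nc2n(-c3c(C)cc(C)cc3C)c(Cl)cn12)CC1CC1` gives 9 nM and compound 2 `C=CCN(CC=C)Cc1c(C(F)(F)F)nc2n(-c3c(C)cc(C)cc3C)c(Cl)cn12` gives 13 nM. Compound 4 `Cc1cc(C)c(-n2c(Cl)cn3c(CN4CCC(c5ccccc5)C4)c(C(F)(F)F)nc23)c(C)c1` carries 3-phenylpyrrolidin-1-yl in place of (cyclobutylmethyl)(propyl)amino on a saturated chain carbon bound to an aromatic carbon. All three measured steps altered the amine at this same place, and each was small: a 1.4-fold higher number from compound 1 to compound 2 (0.16 log units; within the scatter) and a 1.7-fold lower number from compound 1 to compound 3 (0.23 log units; within the scatter) stayed within the scatter, and only a 2.5-fold lower number from compound 2 to compound 3 (0.39 log units; beyond the scatter) went beyond it. For compound 4 a step in this assay this assay of about a 1.9-fold higher number from compound 3 to compound 4 (0.28 log units; within the scatter) is therefore expected, which is none beyond the scatter. Compound 4 is estimated at 10 nM, with a range from 3 nM to 40 nM.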

Compound 4, inhibition constant: 610 nM
For compound 4 the middle estimate is 61-fold (1.79 log units) below the measured one; the whole stated range lies below it.
By their numbers in this assay, from the lowest: compounds 3, 1 and 2 (each within the scatter of the next, the first and the last beyond it); then compound 4.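

In this assay, going by these compounds alone, the amine on a saturated chain carbon bound to an aromatic carbon had so far changed the number only slightly, but this place proves sensitive to the amine it carries. With 3-phenylpyrrolidin-1-yl there is a 120-fold higher number from compound 3 to compound 4 (2.06 log units; beyond the scatter) and a 47-fold higher number from compound 2 to compound 4 (1.67 log units; beyond the scatter) and also a 68-fold higher number from compound 1 to compound 4 (1.83 log units; beyond the scatter) in a single change, so all three earlier amines stand well apart from it. The compounds shown do not separate the effect of the phenyl ring from that of the five-membered ring: an unsubstituted pyrrolidin-1-yl or a benzyl(propyl)amino group here would tell them apart. No evidence is available to explain the size of this step.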